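A few compounds are considered here, and "the series" means these few. Any claim that something is new, unique, unknown or untested is made for them only; others in the source may bear on it.

Measured so far in a functional assay on HCT-8 cells (Homo sapiens) for cytotoxicity; a lower number here means that less compound is needed, a higher number that more compound is needed for the effect:

- compound 1 `COC1=C(C)C(=O)/C(=C(O)/C=C/c2ccc(C)cc2)C(=O)C1(C)C`: 4.1 ug/mL
- compound 2 `C=Cc1ccccc1/C=C/C(O)=C1/C(=O)C(C)=C(OC)C(C)(C)C1=O`: 2.1 ug/mL

On these numbers, compound 2 cannot be told apart from compound 1: a 2.0-fold lower number from compound 1 to compound 2 (0.29 log units; within the scatter) stays within the scatter. Compound 3 `COC1=C(C)C(=O)/C(=C(O)/C=C/c2ccco2)C(=O)C1(C)C` has furan-2-yl in place of 2-vinylphenyl, (furan-2-yl in place of 2-vinylphenyl on a double-bonded chain carbon bound to a double-bonded chain carbon). For the measured compounds named here, the only measured step bearing on this is a 2.0-fold lower number from compound 1 to compound 2 (0.29 log units; within the scatter), a swap at the same place that moved the number no further than the scatter. Going by the values given here, no furan-2-yl compound has been measured yet, so the range stays wide. The expected change is a 1.4-fold higher number from compound 2 to compound 3 (0.15 log units; within the scatter), with no clear direction beyond the scatter. For compound 3 the estimated value is 3 ug/mL, with an expected range of 1.2 ug/mL to 7.5 ug/mL.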

Compound 3, concentration for half-maximal effect: 17.5 ug/mL
Compound 3: middle estimate off by 5.8-fold (0.77 log units), on the low side; measured number above the stated range.
By their numbers in this assay, from the lowest: compounds 2 and 1 (each within the scatter of the next); then compound 3.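

In this assay, for the compounds shown here, furan-2-yl is the first swap at this place to move the number beyond the scatter (an 8.3-fold higher number from compound 2 to compound 3 (0.92 log units; beyond the scatter)), and the same holds against the 4-methylphenyl group (a 4.3-fold higher number from compound 1 to compound 3 (0.63 log units; beyond the scatter)). So this place does respond to its group: both rings of carbon only need less compound than the furan-2-yl ring, though those two cannot be told apart from each other. Nothing at hand explains why the furan-2-yl ring needs more compound.

Whether the ring oxygen or the change from a six-membered to a five-membered ring accounts for the step stays open. So does how thiophen-2-yl, pyridin-3-yl or a longer chain would behave at this place.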